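Cytotoxicity notes: from compound 3 to compound 4

The source may hold more compounds than are shown below. What is called first, only, known or untested is meant among the compounds shown, and "the series" means these compounds.

Compound 3 `O=C1CCC(=O)N1C[C@H]1CN(c2ccc(-n3cc(-c4ccccn4)cn3)c(F)c2)C(=O)O1` stands at the top of what this series shows in an ADME assay on HEK293-A cells (Homo sapiens) for cytotoxicity, read by MTT assay, with a stated time of 48 h; on this read-out higher numbers stand for weaker inhibition and lower numbers for stronger inhibition. In this assay compound 3 gives > 400 ug/mL, which is a limit of the assay and not a number. Compound 1 `O=C1O[C@@H](CN2CCCCC2)CN1c1ccc(-n2cc(-c3ccccn3)cn2)c(F)c1` gives > 400 ug/mL in this assay, likewise a limit. Compound 2 `COC(=O)CC1CCN(C[C@H]2CN(c3ccc(-n4cc(-c5ccccn5)cn4)c(F)c3)C(=O)O2)CC1` gives 224 ug/mL in this assay. Read as steps, an at least 1.7-fold lower number from compound 1 to compound 2 (0.25 log units; that floor lies within the scatter), an at least 1.7-fold higher number from compound 2 to compound 3 (0.25 log units; that floor lies within the scatter), and a step that the two limits leave unreadable from compound 1 to compound 3; the picture is shaped by the limit of > 400 ug/mL in this assay, at which 2 of the 3 values shown sit.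

Compound 4 `O=C1O[C@@H](Cn2ccnc2)CN1c1ccc(-n2cc(-c3ccccn3)cn2)c(F)c1` differs from compound 3 by 1H-imidazol-1-yl in place of 2,5-dioxopyrrolidin-1-yl on a saturated chain carbon bound to a saturated ring carbon. Among the measured compounds shown here, the step that bears on it is the one in which the same saturated chain carbon was changed, an at least 1.7-fold higher number from compound 2 to compound 3 (0.25 log units; that floor lies within the scatter), with a floor within the scatter; no measured step on this position exceeds the scatter. No step beyond the scatter is therefore expected in this assay, and compound 4 is estimated to show a number no higher from compound 3 to compound 4 (the limit leaves the size open). Compound 4 is expected at 400 ug/mL, within 200 ug/mL to 800 ug/mL, most probably reported again only as a limit.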

Compound 4, half-maximal inhibitory concentration: > 400 ug/mL
Compound 4 gave a limit, no number; the forecaster's own chance of this, stated with the estimate: 70%; the middle value sits exactly at the limit.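

Compound 4 gives > 400 ug/mL in this assay, a limit of the assay and not a number, so a five-membered aromatic ring, 1H-imidazol-1-yl, on the saturated chain carbon now reads the same way as the non-aromatic rings piperidin-1-yl and 2,5-dioxopyrrolidin-1-yl. Among the compounds shown here, the one readable step is an at least 1.7-fold higher number from compound 2 to compound 4 (0.25 log units; that floor lies within the scatter). The steps between compound 4 and compound 1 and between compound 4 and compound 3 cannot be read, and the series offers little room for comparison at this position: the limit of > 400 ug/mL in this assay, at which 3 of the 4 values shown sit.

Whether any group at this place gives a step beyond the scatter stays open, since the lowest number shown is that of compound 2, at 224 ug/mL. From the compounds shown here alone, how a primary amine or a 1,2,3-triazol-1-yl group on the same carbon would read in this assay also remains open.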